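Replacing 2-Methylphenyl with 3-Methylthiophen-2-yl on the Core

The compounds below may be only part of what the source reports. "The series", "measured", "known", "first", "only" and "open" are said of these compounds alone.

Measured compounds:
compound 1 `CCc1ccc(-n2nc(-c3ccccc3)nc2CNc2ccc(C(=O)NO)cc2)cc1` — 38.3%
compound 2 `Cc1ccccc1-c1nc(CNc2ccc(C(=O)NO)cc2)n(-c2ccccc2)n1` — 53.2%
compound 3 `Cc1ccc(-n2nc(-c3ccccc3)nc2CNc2ccc(C(=O)NO)cc2)cc1` — 60.7%

All three were tested in an assay on Sf9 cells for inhibition of protein deacetylase HDAC6 (Homo sapiens), read by fluorescence, with a stated time of 40 min, tested at 100 nM; a lower number here means less inhibition, a higher number more inhibition at the concentration tested (going by the name of the read-out). Compound 2 gives the second highest of the three numbers: compound 3 sits closest to it, within the usual scatter, while compound 1 lies further off and beyond it. Among the compounds with values here, the one step that can be traced between two measured compounds is a number 22.4 percentage points higher from compound 1 to compound 3 (beyond the scatter), which concerns the other ring of the core and does not touch the place changed here.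

Compound 4 `Cc1ccsc1-c1nc(CNc2ccc(C(=O)NO)cc2)n(-c2ccccc2)n1` differs from compound 2 in one place: 3-methylthiophen-2-yl in place of 2-methylphenyl on an aromatic carbon. Within the data shown here, no measured step bears on this exchange, so the account can only lean on the narrow spread of the three values already in hand. A step of no size beyond the scatter is therefore expected, and compound 4 is expected to give 50%, within a range from 30% to 70%. The step expected from this estimate is a number 3.2 percentage points lower from compound 2 to compound 4 (within the scatter).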

Compound 4, a percentage reported as inhibition, at one concentration (the size of the read-out at that concentration, not a potency): 72.1%
Estimate against measurement, compound 4: 22.1 percentage points below; the whole stated range lies below it.
By their numbers in this assay, from the lowest: compound 1; then compounds 2 and 3 (each within the scatter of the next); then compound 4.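

This position on the shared core, the aromatic carbon between two ring nitrogen atoms, responds to the ring it carries: in this assay, 3-methylthiophen-2-yl in place of 2-methylphenyl gives a number 18.9 percentage points higher from compound 2 to compound 4 (beyond the scatter) at this place. Within the data shown here, the earlier compounds offered a traceable step only on the other ring, so this is the first sign that a change here also moves the number, and that a five-membered aromatic ring with one hetero atom is accepted here without loss. Nothing measured here accounts for the rise.

The exchange alters ring size and brings in sulfur together, so the compounds shown do not say which of the two matters, or what part the methyl group plays. Unsubstituted thiophen-2-yl, 3-methylfuran-2-yl and a pyridine ring at this place remain open.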